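Pyridin-2-yl replacing 4-methylphenyl on the doubly bonded carbon

This account rests on a few compounds, and the source may have more. Where it says the series, first, only, none or still open, it means among the compounds named here.

Measured compounds:
compound 1, `CN(C)C/C=C/C(=O)Nc1cccc(Nc2nc(N/N=C/c3ccccc3F)ncc2Cl)c1`, gives 3660 nM in an ADME assay on HT-29 cells (Homo sapiens) for inhibition, read by MTT assay, with a stated time of 72 h; on this read-out higher numbers stand for weaker inhibition and lower numbers for stronger inhibition
compound 2, `CN(C)C/C=C/C(=O)Nc1cccc(Nc2nc(N/N=C/c3ccncc3)ncc2Cl)c1`, gives 25200 nM in this assay
compound 3, `C/C(=N\Nc1ncc(Cl)c(Nc2cccc(NC(=O)/C=C/CN(C)C)c2)n1)c1ccc(C)cc1`, gives 11800 nM in this assay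

Compound 3 holds the second highest of the three numbers. Compound 2 is nearest, separated by the step of a 2.1-fold lower number from compound 2 to compound 3 (0.33 log units; beyond the scatter), and compound 1 is furthest, separated by the step of a 3.2-fold higher number from compound 1 to compound 3 (0.51 log units; beyond the scatter).

Compound 4, `C/C(=N\Nc1ncc(Cl)c(Nc2cccc(NC(=O)/C=C/CN(C)C)c2)n1)c1ccccn1`, differs from compound 3 in one place: pyridin-2-yl in place of 4-methylphenyl on a carbon with a double bond to nitrogen. Going by the values given here, two measured steps bear on this. In the step of a 6.9-fold higher number from compound 1 to compound 2 (0.84 log units; beyond the scatter) a ring of carbon only gave way to a ring with one nitrogen, and the number rose. In the step of a 2.1-fold lower number from compound 2 to compound 3 (0.33 log units; beyond the scatter) a ring with one nitrogen gave way to a ring of carbon only, and the number fell. Both point the same way: a ring with one nitrogen on that carbon goes with a higher number, that is, weaker inhibition. Among the compounds with values here, no measured pair tests pyridin-2-yl itself, so the size is uncertain. For compound 4 a modest rise in this assay is expected, about a 2.1-fold higher number from compound 3 to compound 4 (0.33 log units; beyond the scatter), giving an estimated 25000 nM with a range from 8000 nM to 80000 nM.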

Compound 4, half-maximal inhibitory concentration: 120 nM
Estimate against measurement, compound 4: 210-fold (2.32 log units) above, and the stated range ends above it.
By their numbers in this assay, from the lowest: compound 4; then compound 1; then compound 3; then compound 2.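

In this assay the change to pyridin-2-yl gives a 98-fold lower number from compound 3 to compound 4 (1.99 log units; beyond the scatter) and so breaks the earlier link between a ring with one nitrogen on this carbon and weaker inhibition. Compound 2 also carries a ring with one nitrogen, yet the listed step is a 210-fold lower number from compound 2 to compound 4 (2.32 log units; beyond the scatter) and the comparison with the 2-fluorophenyl compound is a 31-fold lower number from compound 1 to compound 4 (1.48 log units; beyond the scatter), which makes compound 4 the strongest inhibitor of the four in this read-out. Nothing measured here explains this large drop.

The compounds shown leave open whether pyridin-2-yl alone accounts for the low number or whether it depends on the saturated chain carbon on the doubly bonded carbon. They also leave open how pyridin-3-yl would behave there, and whether an amine or a methoxy group on the pyridin-2-yl ring would keep the number low.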